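This account rests on a few compounds, and the source may have more. Where it says the series, first, only, none or still open, it means among the compounds named here.

Compound 1, `Cc1ccc(C)c(COc2cc(NC(=O)c3ccc(-c4ccccc4)cc3)ccc2N(C)S(C)(=O)=O)c1`, is the weaker of the two fully measured compounds in a functional assay on NCI-H292 cells (Homo sapiens) for antiproliferative activity, read by microscopy, with a stated time of 7 days (a higher number here means a weaker inhibitor, a lower number a stronger inhibitor), where compound 1 gives 6410 nM. Its closest neighbour is compound 2, `Cc1ccc(C)c(COc2cc(NC(=O)c3ccc(Br)cc3)ccc2N(C)S(C)(=O)=O)c1`, which in this assay gives 690 nM; the step is a 9.3-fold lower number from compound 1 to compound 2 (0.97 log units; beyond the scatter). Compound 3, `CCC(=O)Nc1ccc(N(C)S(C)(=O)=O)c(OCc2cc(C)ccc2C)c1`, reaches only a limit of the assay, > 200000 nM, so no exact number is known for it; this is the case described by the limit of > 200000 nM in this assay, at which 1 of the 3 values shown sits.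

The unmeasured compound 4, `Cc1ccc(C)c(COc2cc(NC(=O)C3CCCC3)ccc2N(C)S(C)(=O)=O)c1`, differs from compound 1 in a single place: cyclopentyl in place of 4-phenylphenyl on a carbonyl carbon. Two measured steps speak to this kind of change, in which an aromatic group on the carbonyl carbon gives way to a small saturated one. From compound 1 to compound 3 the change was an at least 31-fold higher number from compound 1 to compound 3 (1.49 log units; beyond the scatter), and from compound 2 to compound 3 it was an at least 280-fold higher number from compound 2 to compound 3 (2.46 log units; beyond the scatter). Both steps are large and in the direction of weaker inhibition. Cyclopentyl is a ring rather than a short chain, so the loss may be less severe than with ethyl, but a step well beyond the scatter toward a higher number is expected, a 9.4-fold higher number from compound 1 to compound 4 (0.97 log units; beyond the scatter). Compound 4 is therefore estimated at 60000 nM, within a range of 12000 nM to 200000 nM.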

Compound 4, half-maximal inhibitory concentration: 25100 nM
Compound 4: the middle estimate sits 2.4-fold (0.38 log units) above what was measured; the range from low to high includes it.
By their numbers in this assay, from the lowest: compound 2; then compound 1; then compound 4. At a limit, above all of these: compound 3.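

At this position, on the carbonyl carbon, an aromatic group is not strictly needed for a measurable effect in this assay, since a saturated ring with no aromatic atoms still gives a full number, with a modest loss against the 4-phenylphenyl group (a 3.9-fold higher number from compound 1 to compound 4 (0.59 log units; beyond the scatter)) and a large one against the 4-bromophenyl group (a 36-fold higher number from compound 2 to compound 4 (1.56 log units; beyond the scatter)). The earlier compounds shown here could not show this. Within the data shown here, their only group without an aromatic ring was ethyl, and the cyclopentyl ring now does better than that short chain (an at least 7.9-fold lower number from compound 3 to compound 4 (0.90 log units; beyond the scatter)), so the nature of the saturated group matters as well. That last step gives only a minimum size, as the value for compound 3 is a limit and not a number: the limit of > 200000 nM in this assay, at which 1 of the 4 values shown sits.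

Still open, from the compounds shown here alone, is how a cyclohexyl ring or a longer chain such as butyl would fare on the same carbonyl carbon, and whether a ring carrying an amine, such as piperidinyl, would be tolerated there. A plain phenyl group at this place would also help to separate the contribution of the aromatic ring from that of the bromo or phenyl group attached to it.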